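The source may hold more compounds than are shown below. What is called first, only, known or untested is meant among the compounds shown, and "the series" means these compounds.

Measured compounds:
- compound 1, `Cc1c(Oc2cccc(/C=C3\SC(=O)NC3=O)c2)ncnc1OC1CCN(C(=O)OCc2ccccc2)CC1`: 138%
- compound 2, `CCOC(=O)N1CCC(Oc2cc(Oc3cccc(/C=C4\SC(=O)NC4=O)c3)ncn2)CC1`: 43.3%
- compound 3, `CC(C)(C)OC(=O)N1CCC(Oc2cc(Oc3cccc(/C=C4\SC(=O)NC4=O)c3)ncn2)CC1`: 78.3%

In a functional assay on CHO-K1 cells for agonist activity at Glucose-dependent insulinotropic receptor (Homo sapiens), read by cAMP accumulation and immunoassay, with a stated time of 1 h (a lower number here means a smaller maximal response, a higher number a larger maximal response), compound 3 stands second highest of the three numbers; compound 2 lies below it and compound 1 above it, both gaps beyond the scatter. For the measured compounds named here, the one measured step that changes the same group is a number 35 percentage points higher from compound 2 to compound 3 (beyond the scatter), a large rise.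

Compound 4, `O=C1NC(=O)/C(=C/c2cccc(Oc3cc(OC4CCN(C(=O)OCc5ccccc5)CC4)ncn3)c2)S1`, is not yet measured. It differs from compound 3 in one place: benzyl in place of tert-butyl on an oxygen next to a carbonyl group. This is a change of the same ester substituent that was varied between compound 2 and compound 3, so that step bears on it directly. Compound 1 also carries a benzyloxycarbonyl and gives 138%, but it differs from compound 4 in a second place as well, so only its value can be taken as a pointer, not a step.

On this basis a further rise in this assay beyond the scatter is expected for compound 4, estimated as a number 36.7 percentage points higher from compound 3 to compound 4 (beyond the scatter). The expected value for compound 4 is 115%, within a range of 80% to 150%.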

Compound 4, largest response reached (Emax), in percent of the reference or control that the assay uses: 98.3%
Beside the measured number, compound 4's estimate is 16.7 percentage points above it; measured number inside the range.
By their numbers in this assay, from the lowest: compound 2; then compound 3; then compound 4; then compound 1.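

In this assay benzyl in place of tert-butyl on an oxygen next to a carbonyl group raises the maximal response further (a number 20 percentage points higher from compound 3 to compound 4 (beyond the scatter)). Among the three substituents compared at this place, the order runs ethyl, tert-butyl, benzyl, and the whole span is wide (a number 55 percentage points higher from compound 2 to compound 4 (beyond the scatter)), so branching as in tert-butyl is not needed for a higher response. With benzyl held fixed, the methyl on the aromatic carbon can now be read on its own, and hydrogen in its place costs more than the change of ester substituent gains (a number 39.7 percentage points lower from compound 1 to compound 4 (beyond the scatter)).

Nothing measured here accounts for these differences. Still open, as far as these compounds go, are whether a longer chain such as phenethyl, or an amine nitrogen in place of the oxygen, continues the rise, and whether the methyl adds as much alongside ethyl or tert-butyl.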